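The source may hold more compounds than are shown below. What is called first, only, known or untested is meant among the compounds shown, and "the series" means these compounds.

Measured compounds and their values:
- compound 1, `COc1cc(C2=NCCN2)cc2cc(-c3ccc(C4=NCCN4)cc3)oc12`: 19900 nM
- compound 2, `Oc1cc(C2=NCCN2)cc2cc(-c3ccc(C4=NCCN4)cc3)oc12`: > 203000 nM
- compound 3, `COc1cc(C(=N)N)ccc1-c1cc2cc(C(=N)N)ccc2o1`: 157000 nM

In an ADME assay on L6 cells (Rattus norvegicus) for cytotoxicity (on this read-out higher numbers stand for weaker inhibition and lower numbers for stronger inhibition), compound 1 gives 19900 nM. For compound 2 the assay reports only a limit, > 203000 nM, and no number. Compound 3, built on a different core, gives 157000 nM in this assay.

The change from compound 1 to compound 2 is hydrogen in place of methyl on an oxygen on an aromatic ring. It produced an at least 10-fold higher number from compound 1 to compound 2 (1.00 log units; beyond the scatter), so the loss of the methyl on that oxygen went with a clearly weaker effect on the cells, to the point that only the limit of > 203000 nM in this assay, at which 1 of the 3 values shown sits, could be stated.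

Compound 4, `N=C(N)c1ccc(-c2cc3cc(C(=N)N)ccc3o2)c(O)c1`, has not yet been measured. Going by the values given here, it differs from compound 3 by hydrogen in place of methyl on an oxygen on an aromatic ring, the same change as the one from compound 1 to compound 2, at the same kind of place. How the core of compound 3 differs from that of compound 1 is not broken down here.

Compound 3 already stands at the weaker end, with a value beyond the scatter above compound 1. Because of an at least 10-fold higher number from compound 1 to compound 2 (1.00 log units; beyond the scatter) the expectation for compound 4 is a further move toward weaker inhibition, an estimated 2.5-fold higher number from compound 3 to compound 4 (0.41 log units; beyond the scatter). Compound 4 is therefore expected to give about 400000 nM in this assay, within 150000 nM to 2000000 nM, and it is quite possible that the assay will again report only a limit rather than a number.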

Compound 4, half-maximal inhibitory concentration: 33300 nM
Compound 4: middle estimate off by 12-fold (1.08 log units), on the high side; the whole stated range lies above it.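

In this assay, the swap of methoxy to hydroxy gives a 4.7-fold lower number from compound 3 to compound 4 (0.67 log units; beyond the scatter), whereas on the other core the same swap moved the number the opposite way, and the two results clearly disagree: the same change on two cores in this assay, an at least 10-fold higher number (1.00 log units; beyond the scatter) from compound 1 to compound 2 and a 4.7-fold lower number (0.67 log units; beyond the scatter) from compound 3 to compound 4, at least 48-fold (1.68 log units) apart, beyond the scatter of two such steps

This shows that, in this series, the step seen on one core cannot simply be carried over to the other, since not even its direction was kept. Going by these compounds alone, compound 2 gives only a limit, > 203000 nM, so the step leading to it has no exact size, and with only two matched pairs the data do not show which difference between the two cores goes with the change in direction, or why the direction differs.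

The compounds shown leave open how a third core would respond to the same swap, and whether it would follow either of the two results seen here. They also leave open what would happen if an amine or a carboxylic acid stood in the same place on an aromatic ring, or if a longer chain replaced the methyl on the oxygen, and whether either group would give the same direction on both cores.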